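Replacing Butyl with Chlorophenyl on an Aromatic Nitrogen

This account rests on a few compounds, and the source may have more. Where it says the series, first, only, none or still open, it means among the compounds named here.

Of the compounds shown here, two have so far been tested in a functional assay on the whole organism (strain Wistar) for inhibition, with Rattus norvegicus as the target, read by paw edema, with a stated time of 4 h, at a dose of 10 mg/kg by the oral route; a higher number here means more inhibition at the dose given (going by the name of the read-out), a lower number less inhibition. Compound 1 `Clc1ccc(-c2nnc(COc3ccc(-c4ccccc4)cc3)o2)c(Cl)c1` gives 57.6%. Compound 2 `CCCCn1c(S)nnc1COc1ccc(-c2ccccc2)cc1` gives 81.8% in this assay, the higher of the two numbers, and its gap to compound 1 lies beyond the usual scatter of repeated measurements. Compound 3 `Sc1nnc(COc2ccc(-c3ccccc3)cc2)n1-c1ccc(Cl)cc1` has not been measured yet. It differs from compound 2 in a single place: 4-chlorophenyl in place of butyl on an aromatic nitrogen. For the measured compounds named here, no measured pair shows what this particular exchange does, so any expectation must rest on compound 2 and the one other number available. The step of a number 11.8 percentage points lower from compound 2 to compound 3 (beyond the scatter) is expected to be a modest decrease, close to the edge of the usual scatter rather than clearly beyond it. Going by the values given here, compound 1, the only other compound with a chlorine-bearing benzene ring, gives 57.6%, which tempers the expectation. Compound 3 is therefore estimated at 70%, with a likely range from 50% to 88%.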

Compound 3, a percentage reported as inhibition, in the whole organism at one dose (the size of the read-out at that dose, not a potency): 18.2%
The estimate for compound 3 lay 51.8 percentage points above the measured number; the measured number lies below the stated range.
By their numbers in this assay, from the lowest: compound 3; then compound 1; then compound 2.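

Putting 4-chlorophenyl in place of butyl on the aromatic nitrogen gives a number 63.6 percentage points lower from compound 2 to compound 3 (beyond the scatter) in this assay, a large step from a single change. The group on this nitrogen therefore has a strong bearing on the read-out, even though neither group carries a hydrogen-bond donor, a hydrogen-bond acceptor or a net charge; what enters brings an aromatic ring, a chlorine and more heavy atoms in place of an open chain. Nothing available explains why the number falls so far.

On these data alone, it remains open whether the drop comes from the benzene ring itself or from the chlorine it carries, and a plain phenyl group would help separate the two. Equally open, as far as these compounds go, is how this position responds to other chains, such as a hexyl chain or a short chain ending in an amine.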